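Methyl for chloro on a kinase-type amide scaffold

The source may hold more compounds than are shown below. What is called first, only, known or untested is meant among the compounds shown, and "the series" means these compounds.

Measured compounds:
- compound 1, `O=C(Nc1ccc(Oc2ccnc3[nH]ccc23)cc1)c1nccc(-c2ccc(F)cc2)n1`: "not active" (no number reported)
- compound 2, `O=C(Nc1ccc(Oc2ccnc3[nH]ccc23)cc1)c1cc(-c2ccc(Cl)cc2)ncn1`: 6530 nM

Of the compounds shown here, two sharing one core have been tested in a functional assay on A549 cells (Homo sapiens) for cytotoxicity, read by MTT assay, with a stated time of 72 h; on this read-out higher numbers stand for weaker inhibition and lower numbers for stronger inhibition. Compound 1 is recorded as "not active" (no number reported) without a number. For the measured compounds named here, compound 2 is the only compound with a stated number, giving 6530 nM in this assay, so it is the sole reference point here.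

Compound 3, `Cc1ccc(-c2cc(C(=O)Nc3ccc(Oc4ccnc5[nH]ccc45)cc3)ncn2)cc1`, differs from compound 2 in one place: methyl in place of chloro on an aromatic carbon. Going by the values given here, no measured pair shows what this exchange does on this core, so the expected step is small and uncertain. A step of modest size, if any, is expected, and a 1.2-fold higher number from compound 2 to compound 3 (0.09 log units; within the scatter) is the estimated change from compound 2 to compound 3. Compound 3 is therefore expected to give about 8000 nM in this assay, with a plausible range from 3000 nM to 22000 nM.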

Compound 3, half-maximal inhibitory concentration: 5410 nM
For compound 3 the middle estimate is 1.5-fold (0.17 log units) above the measured one, and the stated range covers the measured number.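

In this assay, the exchange of 4-chlorophenyl for 4-methylphenyl gives a 1.2-fold lower number from compound 2 to compound 3 (0.08 log units; within the scatter) and so does not separate the two groups on this core. This is the first pair shown that differs in one place only, and it indicates that, at this position on the shared core, chloro and methyl give readings that cannot be told apart. Nothing at hand explains this likeness between the two groups. From the compounds shown here alone, both groups count a single heavy atom, so it remains open what a larger or different group in the same place, such as an amine, a carboxylic acid or a longer carbon chain, would do to the cell reading. Compound 1 differs from compound 2 and compound 3 in more than one place, so its entry cannot settle that question.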